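Adding a second hydroxy to a phenyl-naphthol

A few compounds are considered here, and "the series" means these few. Any claim that something is new, unique, unknown or untested is made for them only; others in the source may bear on it.

Measured so far:
- compound 1, `Oc1ccc2cc(-c3ccccc3O)ccc2c1`: < 10%
- compound 2, `Oc1cccc(-c2ccc3ccccc3c2)c1`: 12%
- compound 3, `Oc1cccc2cc(-c3ccccc3)ccc12`: 20%

Of the compounds shown here, three have been tested in an assay for binding affinity to 17-beta-hydroxysteroid dehydrogenase type 2 (Homo sapiens), with a stated time of 20 min, tested at 1 uM; on this read-out higher numbers stand for more inhibition at the one concentration tested (going by the name of the read-out) and lower numbers for less inhibition. Compound 1, `Oc1ccc2cc(-c3ccccc3O)ccc2c1`, gives only a limit of the assay, < 10%, and no number. Compound 2, `Oc1cccc(-c2ccc3ccccc3c2)c1`, gives 12% in this assay. Compound 3, `Oc1cccc2cc(-c3ccccc3)ccc12`, gives 20% in this assay and so sits at the top of the two numbers shown, yet its gap to compound 2 lies within the usual scatter, so the two cannot be ranked against each other.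

The next compound, compound 4, `Oc1cccc(-c2ccc3c(O)cccc3c2)c1`, is reached from compound 3 by one change: hydroxy in place of hydrogen on an aromatic carbon. Compound 4 carries the hydroxy that compound 2 has on its phenyl ring together with the hydroxy that compound 3 has on its shared core. Nothing in the three results tells how these two groups act when they are combined, and compound 1, which also carries two hydroxy groups, gives only a limit, (the limit of < 10% in this assay, at which 1 of the 3 values shown sits).

The expected step is a number 5 percentage points higher from compound 3 to compound 4 (within the scatter). Compound 4 is estimated at 25%, with a range from 8% to 45%, in this assay.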

Compound 4, a percentage reported as inhibition, at one concentration (the size of the read-out at that concentration, not a potency): 32%
For compound 4 the middle estimate is 7 percentage points below the measured one, within the range that was stated.
By their numbers in this assay, from the lowest: compounds 2 and 3 (each within the scatter of the next); then compound 4. At a limit, below all of these: compound 1.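

The result shows that in this assay the two hydroxy groups together give a reading that neither gives alone, whichever single-hydroxy compound is taken as the starting point. Placing a hydroxy on the phenyl ring, on an aromatic carbon meta to a large group, gives a number 12 percentage points higher from compound 3 to compound 4 (beyond the scatter), and placing one on the shared core gives a number 20 percentage points higher from compound 2 to compound 4 (beyond the scatter); these are the first changes in the series that can be told apart from the usual scatter, though both remain modest. Nothing shown gives a cause for this rise.

From the compounds shown here alone, it remains open whether another group at the same place, such as an amine, a methoxy group or a fluorine atom, would give a similar step, and whether a hydroxy elsewhere on the phenyl ring would do the same. Going by these compounds, the read-out also comes from one concentration, so how these compounds would rank by potency is still unknown.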